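Selenium to sulfur swap on a bis-acyl isothiourea core

The source may hold more compounds than are shown below. What is called first, only, known or untested is meant among the compounds shown, and "the series" means these compounds.

Compound 1, `C[Se]/C(=N\C(=O)c1cc2ccccc2s1)NC(=O)c1cc2ccccc2s1`, in a functional assay on K562 cells (Homo sapiens) for cytotoxicity, read by MTT assay, with a stated time of 72 h; a lower number here means that less compound is tolerated, a higher number that more compound is tolerated: 89600 nM
Compound 2, `CS/C(=N\C(=O)c1cc(-c2ccccc2)nc2ccccc12)NC(=O)c1cc(-c2ccccc2)nc2ccccc12`, in this assay: > 100000 nM, which is a limit of the assay and not a number
Compound 3, `C[Se]/C(=N\C(=O)c1ccno1)NC(=O)c1ccno1`, in this assay: > 100000 nM, again a limit rather than a number

Compound 1 is the only one of the three to give a number in this assay; the other two sit at the limit of > 100000 nM in this assay, at which 2 of the 3 values shown sit. Among the compounds with values here, no pair of the measured compounds differs in one place, so no measured step is available.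

Compound 4, `CS/C(=N\C(=O)c1cc2ccccc2s1)NC(=O)c1cc2ccccc2s1`, carries the change a group of 2 heavy atoms (1 carbon, 1 sulfur; no ring) in place of a group of 2 heavy atoms (1 carbon, 1 selenium; no ring), on a carbon with a double bond to nitrogen relative to compound 1. Compound 2 already shows the methylsulfanyl group on a different core, and compound 2 reaches only a limit in this assay. With no measured step of this kind in hand, compound 4 is expected to tolerate somewhat more compound than compound 1, with a modest expected step of a 1.7-fold higher number from compound 1 to compound 4 (0.22 log units; within the scatter). The estimate for compound 4 in this assay is 150000 nM, with a range from 60000 nM to 400000 nM, and a real chance that only a limit is reported.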

Compound 4, concentration lethal to 50% of the cells: 98600 nM
For compound 4 the middle estimate is 1.5-fold (0.18 log units) above the measured one; the range from low to high includes it.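

Within the data shown here, the exchange of the selenium-bearing group for methylsulfanyl, on a carbon with a double bond to nitrogen, gives the first measured step at this place, with the rest of the structure unchanged: in this assay it reads a 1.1-fold higher number from compound 1 to compound 4 (0.04 log units; within the scatter). On this core, then, no difference can be claimed between the two groups, and the number seen with compound 1 does not depend on selenium being present. Both numbers also stand close to the limit of the read-out, which is a limit and not a number: the limit of > 100000 nM in this assay, at which 2 of the 4 values shown sit.

What the compounds shown leave open is whether the same exchange would also read as flat on a core with values well clear of that limit. They also leave open how an amine or a longer chain on this carbon would read.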